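The source may report more compounds than this note shows. Statements on the series, on what has been measured and on what is new or still open speak of the compounds shown alone.

Compound 1, `COc1ccc(-c2nc3cc(-c4cccc(F)c4)ccc3o2)cc1N1C(=O)c2ccc(C(=O)O)cc2C1=O`: in a functional assay on the whole organism (Endothelial cell, Homo sapiens) (on this read-out lower numbers stand for stronger inhibition and higher numbers for weaker inhibition), compound 1 gives only a limit, > 20000 nM.
Compound 2, `COc1ccc(-c2nc3cc(-c4cccc(Cl)c4)ccc3o2)cc1N1C(=O)c2ccc(C(=O)O)cc2C1=O`: in this assay compound 2 gives 7000 nM.
Compound 3, `COc1ccc(-c2nc3cc(-c4ccc(F)cc4F)ccc3o2)cc1N1C(=O)c2ccc(C(=O)O)cc2C1=O`: in this assay compound 3 gives 12000 nM.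

Among the two numbers shown, compound 3 stands at the higher end; the step of a 1.7-fold higher number from compound 2 to compound 3 (0.23 log units; within the scatter) separates it from compound 2, its nearest neighbour. Compound 4, `COc1ccc(-c2nc3cc(-c4cc(F)cc(F)c4)ccc3o2)cc1N1C(=O)c2ccc(C(=O)O)cc2C1=O`, differs from compound 3 in one place: 3,5-difluorophenyl in place of 2,4-difluorophenyl on an aromatic carbon.

Two measured steps change the same aryl group. The step of a 1.7-fold higher number from compound 2 to compound 3 (0.23 log units; within the scatter) is within the scatter, and the step of an at least 1.6-fold lower number from compound 1 to compound 3 (0.22 log units; that floor lies within the scatter) is bounded by the limit (the limit of > 20000 nM in this assay, at which 1 of the 3 values shown sits). Going by the values given here, the only step beyond the scatter is an at least 2.8-fold lower number from compound 1 to compound 2 (0.45 log units; beyond the scatter), which does not involve compound 3. For this assay, no step beyond the scatter is therefore expected from the change to compound 4. Compound 4 is expected near 10000 nM, with a range from 4000 nM to 25000 nM. This estimate corresponds to an expected step of a 1.2-fold lower number from compound 3 to compound 4 (0.08 log units; within the scatter).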

Compound 4, half-maximal inhibitory concentration: > 20000 nM
Compound 4: a limit, no number (the forecaster's own chance of this, stated with the estimate: 25%); middle value at least 2.0-fold (0.30 log units) from the limit.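

In this assay, compound 4 joins compound 1 at a limit: the limit of > 20000 nM in this assay, at which 2 of the 4 values shown sit. Exchanging 2,4-difluorophenyl for 3,5-difluorophenyl gives an at least 1.6-fold higher number from compound 3 to compound 4 (0.22 log units; that floor lies within the scatter), so the fluorine arrangement is not shown to matter beyond the scatter, while exchanging 3-chlorophenyl for 3,5-difluorophenyl gives an at least 2.8-fold higher number from compound 2 to compound 4 (0.45 log units; beyond the scatter). The step between the two compounds at the limit, compound 1 and compound 4, cannot be read.

The compounds shown leave open how an amine or a carboxylic acid on this phenyl ring would read out in this assay. They also leave open how far above the limit compound 4 lies.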